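The source may report more compounds than this note shows. Statements on the series, on what has been measured and on what is new or still open speak of the compounds shown alone.

Working notes on the series, all read in a functional assay on L02 cells (Homo sapiens) for inhibition, read by Griess assay, with stated times of 1 h and 24 h (a lower number here means a stronger inhibitor, a higher number a weaker inhibitor), as the only measure. Compound 3 (`COc1cc(/C=C/c2nc(NCc3ccccc3Cl)c3sccc3n2)cc(OC)c1OC`) reads > 1000000 nM as a limit of the assay and not a number. Compound 1 (`COc1cc(/C=C/c2nc(N(C)C)c3sccc3n2)cc(OC)c1OC`) reads > 1000000 nM as a limit too. Going by the values given here, compound 2 (`COc1cc(/C=C/c2nc(Nc3ccc(C(F)(F)F)cc3)c3sccc3n2)cc(OC)c1OC`) reads 436000 nM as the one true number so far. Compound 3 therefore sits at the limit of > 1000000 nM in this assay, at which 2 of the 3 values shown sit, and has no exact place on the scale.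

Compound 4 (`COc1cc(/C=C/c2nc(NC(C)C)c3sccc3n2)cc(OC)c1OC`) follows from compound 3 by isopropyl in place of 2-chlorobenzyl on a nitrogen on an aromatic ring with isopropyl in place of 2-chlorobenzyl on a nitrogen on an aromatic ring. The measured steps at this same place are an at least 2.2-fold lower number from compound 1 to compound 2 (0.36 log units; beyond the scatter) and an at least 2.2-fold higher number from compound 2 to compound 3 (0.36 log units; beyond the scatter) while a step that the two limits leave unreadable from compound 1 to compound 3 gives nothing to read. Only the (4-(trifluoromethyl)phenyl)amino group of compound 2 has left the limit so far. Among the compounds with values here, the closest precedent is compound 1 at > 1000000 nM as a limit, since its dimethylamino group also has no ring. A step of no readable size is therefore expected, estimated as a number no higher from compound 3 to compound 4 (the limit leaves the size open) and probably ending at the limit again. Compound 4 is estimated at 1000000 nM with 400000 nM to 2500000 nM as its expected range.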

Compound 4, half-maximal inhibitory concentration: > 1000000 nM
Compound 4: no number, only a limit (the forecaster's own chance of this, stated with the estimate: 65%); the middle value lies on the limit itself.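

In this assay, compound 4 is a limit of the assay and not a number, so isopropyl on this nitrogen gives no readable inhibition. With compound 1 and compound 3 also at the limit, neither a group with no ring nor the ring-bearing 2-chlorobenzyl has left it, and the presence or absence of a ring does not by itself separate the compounds shown. Isopropyl in place of 4-(trifluoromethyl)phenyl gives an at least 2.2-fold higher number from compound 2 to compound 4 (0.36 log units; beyond the scatter), while the steps among compound 1, compound 3 and compound 4 cannot be read, which leaves compound 2 alone with a true number on this scale: the limit of > 1000000 nM in this assay, at which 3 of the 4 values shown sit.

On these data alone, it remains open whether compound 2 owes its number to the phenyl ring or to the trifluoromethyl group on it, a question that a plain phenyl or a 4-methoxyphenyl on the same nitrogen would help to settle. As far as these compounds go, how far compound 1, compound 3 and compound 4 differ from one another beyond the limit also stays unknown.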